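Swapping one small ring for another on a sulfonyl-linked chain

A few compounds are considered here, and "the series" means these few. Any claim that something is new, unique, unknown or untested is made for them only; others in the source may bear on it.

In a functional assay, read by Griess assay, with a stated time of 150 min, tested at 75 ug/mL (on this read-out higher numbers stand for a stronger effect at the one concentration tested and lower numbers for a weaker effect), compound 3 `COc1ccc(C2=NN(c3ccccc3)C(c3ccc(C)cc3)C2S(=O)(=O)CC2=NCCS2)cc1` gives 44.9% and compound 2 `COc1ccc(C2=NN(c3ccccc3)C(c3ccc(C)cc3)C2S(=O)(=O)CC2=NCCO2)cc1` gives 64.9%. The two differ by a single change, (a group of 5 heavy atoms (3 carbon, 1 nitrogen, 1 oxygen; one five-membered non-aromatic ring with 2 hetero atoms) in place of a group of 5 heavy atoms (3 carbon, 1 nitrogen, 1 sulfur; one five-membered non-aromatic ring with 2 hetero atoms), on a saturated chain carbon bound to a sulfonyl sulfur), and this change gave a number 20 percentage points higher from compound 3 to compound 2 (beyond the scatter). Compound 1 `O=S(=O)(CC1=NCCS1)C1C(c2ccccc2)=NN(c2ccccc2)C1c1ccccc1` carries the same kind of ring, and in this assay compound 1 was reported as "not active" (no number reported), with no number. How the core of compound 1 differs from the core of compound 3 is not broken down here. Compound 4 `O=S(=O)(CC1=NCCO1)C1C(c2ccccc2)=NN(c2ccccc2)C1c1ccccc1` is not yet measured; it relates to compound 1 as compound 2 relates to compound 3, through the same change, (a group of 5 heavy atoms (3 carbon, 1 nitrogen, 1 oxygen; one five-membered non-aromatic ring with 2 hetero atoms) in place of a group of 5 heavy atoms (3 carbon, 1 nitrogen, 1 sulfur; one five-membered non-aromatic ring with 2 hetero atoms), on a saturated chain carbon bound to a sulfonyl sulfur). Since compound 1 has no number, the step to compound 4 cannot be sized in the same way, but a rise of about the size seen from compound 3 to compound 2 would be a reasonable expectation, starting from a low point. Compound 4 is therefore expected to give about 20% in this assay, with a plausible range from 0% to 45%.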

Compound 4, a percentage reported as activity, at one concentration (the size of the read-out at that concentration, not a potency): 51.4%
Compound 4: middle estimate off by 31.4 percentage points, on the low side, outside the stated range (above it).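

Compound 1 has no number, and the change from compound 1 to compound 4 cannot be read as a step. From the compounds shown here alone, how much that ring swap matters on this core stays open. No evidence explains the result.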